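Aryloxypropyl series: chloro to dimethyl swap on the aromatic ring

The source may hold more compounds than are shown below. What is called first, only, known or untested is meant among the compounds shown, and "the series" means these compounds.

Measured so far:
compound 1 `NC1=NC2(CCOCC2)N(OCCCOc2cccc(Cl)c2)C(N)=N1` — 1020 nM
compound 2 `Cc1ccc(OCCCON2C(N)=NC(N)=NC23CCOCC3)cc1` — "not determined" (no result reported)
compound 3 `NC1=NC2(CCOCC2)N(OCCCOc2ccc(Br)cc2)C(N)=N1` — "not determined" (no result reported)

Among the compounds with values here, in a functional assay on MDA-MB-231 cells (Homo sapiens) for antiproliferative activity, read by MTT assay, with a stated time of 72 h (a lower number here means a stronger inhibitor, a higher number a weaker inhibitor), compound 1 gives 1020 nM, the only number available; compound 2 gives "not determined" (no result reported) and compound 3 gives "not determined" (no result reported), so no step between measured compounds can be drawn. Compound 4 `Cc1cc(C)cc(OCCCON2C(N)=NC(N)=NC23CCOCC3)c1` differs from compound 1 in one place: 3,5-dimethylphenyl in place of 3-chlorophenyl on an oxygen on a saturated carbon. Within the data shown here, with no comparable step on record, the expectation rests on compound 1 alone, and the change is expected to move this assay little, if at all, so a step within the usual scatter is the working assumption. Compound 4 is therefore estimated at 1400 nM (range 500 nM to 4000 nM), which corresponds to an expected step of a 1.4-fold higher number from compound 1 to compound 4 (0.14 log units; within the scatter).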

Compound 4, half-maximal inhibitory concentration: 3570 nM
For compound 4 the middle estimate is 2.6-fold (0.41 log units) below the measured one; the range from low to high includes it.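

In this assay, within the data shown here, the aryl group on an oxygen on a saturated carbon proves not to be indifferent: 3,5-dimethylphenyl in place of 3-chlorophenyl gives a 3.5-fold higher number from compound 1 to compound 4 (0.54 log units; beyond the scatter), the first readable step, and it lies beyond the scatter. The change costs activity modestly rather than abolishing it. No available evidence bears on the reason for this step.

Steps involving compound 2 and compound 3 cannot be read. From the compounds shown here alone, whether a 3-methoxyphenyl group or a longer chain would hold or improve on compound 1 remains open.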